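The compounds below may be only part of what the source reports. "The series", "measured", "known", "first", "only" and "open" are said of these compounds alone.

Measured compounds:
compound 1, `Cc1cccc(-c2nn(-c3ccc(F)cc3F)cc2CNCCN2CCN(C)CC2)c1`: in an ADME assay on Huh-7 cells (Homo sapiens) for cytotoxicity (on this read-out lower numbers stand for higher toxicity in this test and higher numbers for lower toxicity in this test), compound 1 reaches only a limit, > 20000 nM.
compound 2, `CN1CCN(CCNCc2cn(-c3ccc(F)cc3F)nc2C2CCCCC2)CC1`: in this assay compound 2 likewise reaches only a limit, > 20000 nM.
compound 3, `CN1CCN(CCNCc2cn(-c3ccc(F)cc3F)nc2-c2ccc(C(F)(F)F)cc2)CC1`: in this assay compound 3 gives 20000 nM.

Going by the values given here, compound 3 holds the only true number among the three; the other two are limits. What the measured steps rest on is the limit of > 20000 nM in this assay, at which 2 of the 3 values shown sit. The step of a number no higher from compound 1 to compound 3 (the limit leaves the size open) and the step of a number no higher from compound 2 to compound 3 (the limit leaves the size open) have no readable size, and a step that the two limits leave unreadable from compound 1 to compound 2. Compound 4, `CN1CCN(CCNCc2cn(-c3ccc(F)cc3F)nc2-c2ccccc2Cl)CC1`, differs from compound 3 in one place: 2-chlorophenyl in place of 4-(trifluoromethyl)phenyl on an aromatic carbon. With all measured steps unreadable and every value sitting at the same point, no shift beyond the scatter is expected. For compound 4 the estimate in this assay is 20000 nM, between 10000 nM and 40000 nM, which means an expected step of no change at the digits printed from compound 3 to compound 4 (within the scatter).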

Compound 4, half-maximal cytotoxic concentration: > 20000 nM
Compound 4: a limit, no number (the forecaster's own chance of this, stated with the estimate: 65%); the middle value lies on the limit itself.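

On the aromatic carbon next to the ring nitrogen, 2-chlorophenyl in place of 4-(trifluoromethyl)phenyl gives a number no lower from compound 3 to compound 4 (the limit leaves the size open) in this assay. Compound 4 reaches only a limit, > 20000 nM, so a chlorine-bearing phenyl ring here adds no true number. The steps from compound 1 and from compound 2 to compound 4 join two limits and cannot be read, and the series still rests on one point: the limit of > 20000 nM in this assay, at which 3 of the 4 values shown sit.

Open, on these data alone, is how far past that limit these compounds lie. Also open, as far as these compounds go, is whether an amine or a carboxylic acid on the phenyl ring at this position would give a lower number.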